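Compound 4 expected close to compound 3 in growth inhibition

A few compounds are considered here, and "the series" means these few. Any claim that something is new, unique, unknown or untested is made for them only; others in the source may bear on it.

Compound 1 `COc1cc(CSc2cc(Cl)c(-c3nnc(-c4ccc(Cl)cc4)s3)cc2S(=O)(=O)NC(=N)NO)cc(OC)c1OC`: 9550 nM
Compound 2 `N=C(NO)NS(=O)(=O)c1cc(-c2nnc(-c3ccc(Cl)cc3)s2)c(Cl)cc1SCc1ccccc1`: 1900 nM
Compound 3 `COc1cc(CSc2cc(Cl)c(-c3nc(-c4ccccc4)no3)cc2S(=O)(=O)NC(=N)NO)cc(OC)c1OC`: 6920 nM

In a functional assay on SF-268 cells (Homo sapiens) (on this read-out higher numbers stand for weaker inhibition of growth and lower numbers for stronger inhibition of growth), compound 3 gives 6920 nM, the second highest of the three numbers; it sits within the scatter of compound 1, and the distance to compound 2 lies beyond it. Compound 4 `COc1cc(CSc2cc(Cl)c(-c3nnc(-c4ccccc4)s3)cc2S(=O)(=O)NC(=N)NO)cc(OC)c1OC` is not yet measured. It differs from compound 3 in one place: 5-phenyl-1,3,4-thiadiazol-2-yl in place of 3-phenyl-1,2,4-oxadiazol-5-yl on an aromatic carbon.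

Within the data shown here, one measured step bears on this change. Going from compound 1 to compound 3, where the 5-(4-chlorophenyl)-1,3,4-thiadiazol-2-yl group gave way to 3-phenyl-1,2,4-oxadiazol-5-yl, the number moved by a 1.4-fold lower number from compound 1 to compound 3 (0.14 log units; within the scatter). Compound 4 carries the thiadiazole of compound 1 and the unsubstituted phenyl of compound 3, so it stands between them on that axis. The step of a 5.0-fold lower number from compound 1 to compound 2 (0.70 log units; beyond the scatter) concerns the other end of the molecule and does not bear on this exchange. Compound 3 to compound 4 is therefore expected to show no step beyond the scatter, a 1.1-fold higher number from compound 3 to compound 4 (0.03 log units; within the scatter). Compound 4 is estimated at 7500 nM, within the range 3500 nM to 16000 nM.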

Compound 4, concentration for 50% growth inhibition: 2400 nM
For compound 4 the middle estimate is 3.1-fold (0.49 log units) above the measured one; the whole stated range lies above it.
By their numbers in this assay, from the lowest: compounds 2 and 4 (each within the scatter of the next); then compounds 3 and 1 (each within the scatter of the next).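

Among these compounds, at this aromatic carbon, the ring carrying the phenyl proves to matter: the exchange of 3-phenyl-1,2,4-oxadiazol-5-yl for 5-phenyl-1,3,4-thiadiazol-2-yl gives a 2.9-fold lower number from compound 3 to compound 4 (0.46 log units; beyond the scatter) in this assay and so a change the earlier compounds did not reveal. Hydrogen in place of chloro on an aromatic carbon also counts, with a 4.0-fold lower number from compound 1 to compound 4 (0.60 log units; beyond the scatter) as its step. The earlier step of a 1.4-fold lower number from compound 1 to compound 3 (0.14 log units; within the scatter) therefore concealed two changes pulling in opposite directions, since compound 3 differs from compound 1 in both the ring and the chloro group.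

On these data alone, whether fluoro or a nitrile in place of that chloro group would hold the number of compound 4, and whether a 1,3,4-oxadiazole ring would match the thiadiazole, stays open. Nothing available accounts for the stronger growth inhibition seen with the thiadiazole.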